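Lengthening the Hydroxamic Acid Chain of Compound 1

This account rests on a few compounds, and the source may have more. Where it says the series, first, only, none or still open, it means among the compounds named here.

Values so far in a functional assay on MV4-11 cells (Homo sapiens) for antiproliferative activity, read by CCK-8 assay, with a stated time of 72 h (on this read-out higher numbers stand for weaker inhibition and lower numbers for stronger inhibition), are these:
- Compound 1 `Cn1cc(-c2ccccc2Oc2ccccc2)c2cc(C(=O)NCCCC(=O)NO)[nH]c2c1=O` gives 380 nM here
- Compound 2 `Cn1cc(-c2cccc(C(C)(C)O)c2)c2cc(C(=O)NCc3ccc(C(=O)Nc4ccccc4N)cc3)[nH]c2c1=O` gives 2200 nM here
- Compound 3 `CC(C)Oc1ccccc1-c1cn(C)c(=O)c2[nH]c(C(=O)NCc3ccc(C(=O)Nc4ccccc4N)cc3)cc12` gives 130 nM here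

Compound 1 stands second highest of the three. Compound 4 `Cn1cc(-c2ccccc2Oc2ccccc2)c2cc(C(=O)NCCCCC(=O)NO)[nH]c2c1=O` keeps the core of compound 1 and changes only the chain end: (hydroxycarbamoyl)methyl in place of hydroxycarbamoyl on a saturated chain carbon, three bonds along the chain from an amide-type nitrogen is the whole difference, which amounts to 3-(hydroxycarbamoyl)propyl becoming 4-(hydroxycarbamoyl)butyl. Within the data shown here, the one measured step, a 17-fold lower number from compound 2 to compound 3 (1.23 log units; beyond the scatter), is large, but it swaps a different group elsewhere, so it says nothing about chain length. No step beyond the scatter is therefore expected in this assay, with only a slight lean towards lower numbers. The expected step is a 1.7-fold lower number from compound 1 to compound 4 (0.24 log units; within the scatter) on this estimate. Compound 4 is estimated at 220 nM with an expected range from 70 nM to 700 nM around it.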

Compound 4, half-maximal inhibitory concentration: 180 nM
The estimate for compound 4 lay 1.2-fold (0.09 log units) above the measured number; measured number inside the range.
By their numbers in this assay, from the lowest: compounds 3 and 4 (each within the scatter of the next); then compound 1; then compound 2.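

Changing 3-(hydroxycarbamoyl)propyl to 4-(hydroxycarbamoyl)butyl in this assay gives a 2.1-fold lower number from compound 1 to compound 4 (0.32 log units; beyond the scatter) and so shows that the length of this chain alone can move the number, though only modestly. With just these two chain lengths compared, this is a single step and not yet a trend. Nothing available explains the step. On these data alone, whether a longer chain such as 5-(hydroxycarbamoyl)pentyl would lower the number further or raise it again remains open. So does the effect of a carboxylic acid in place of the hydroxycarbamoyl group.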